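The compounds below may be only part of what the source reports. "The series", "measured", "known", "first", "only" and "open" are said of these compounds alone.

Compound 2 (`O=C(NCc1ccccc1Br)N1C(=O)c2ccccc2S1(=O)=O`) is the point of departure. In a physicochemical assay for pharmacokinetics (a lower number here means that the compound disappears faster, a higher number that the compound lasts longer), compound 2 gives > 166 h as a limit of the assay, not a number. Compound 1 (`CC(NC(=O)N1C(=O)c2ccccc2S1(=O)=O)c1ccccc1`) gives > 166 h and this too is a limit. Compound 3 (`O=C(NCc1ccccc1Cl)N1C(=O)c2ccccc2S1(=O)=O`) gives > 166 h and this is likewise a limit. The evidence so far is therefore the limit of > 166 h in this assay, at which 3 of the 3 values shown sit, and no order can be read among these compounds.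

The move to compound 4 (`O=C(NCC1CCCCC1)N1C(=O)c2ccccc2S1(=O)=O`) is cyclohexyl in place of 2-bromophenyl on a saturated chain carbon bound to an amide-type nitrogen with cyclohexyl in place of 2-bromophenyl on a saturated chain carbon bound to an amide-type nitrogen. Among the measured compounds shown here, the only measured step nearby is a step that the two limits leave unreadable from compound 2 to compound 3 and it has no readable size. It is also a different change, chloro in place of bromo on an aromatic carbon.

With compound 2 resting on > 166 h as a limit, no step beyond the scatter is expected in this assay here. The estimated change is a step that the limit leaves unreadable from compound 2 to compound 4 and it is expected to stay within the scatter. For compound 4 the estimate is 200 h with an expected range from 100 h to 400 h and the result may well be only a limit.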

Compound 4, half-life: > 166 h
Compound 4 ended at the assay's limit; the forecaster's own chance of this, stated with the estimate: 75%; the middle value lies beyond the limit too.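

In this assay compound 4 gives > 166 h, which is a limit of the assay, not a number. The steps to compound 4 from compound 2 and compound 3 therefore cannot be read. The compounds shown leave open any order among them and whether cyclohexyl in place of 2-bromophenyl changes the half-life at all.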